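A few compounds are considered here, and "the series" means these few. Any claim that something is new, unique, unknown or untested is made for them only; others in the source may bear on it.

Measured compounds:
compound 1, `COc1cc2c(Oc3ccc(NC(=O)c4nn(-c5ccccc5C)cc(C)c4=O)cc3)ccnc2cc1OCCCC(=O)NO`: 640 nM
compound 2, `COc1cc2c(Oc3ccc(NC(=O)c4nn(-c5ccccc5F)cc(C)c4=O)cc3F)ccnc2cc1OCCCC(=O)NO`: 1120 nM

In a functional assay on HCT-116 cells (Homo sapiens) for inhibition, read by MTT assay, with a stated time of 72 h (a higher number here means a weaker inhibitor, a lower number a stronger inhibitor), compound 2 gives 1120 nM, the highest of the two numbers recorded. Its nearest neighbour is compound 1, which gives 640 nM in this assay; the gap between the two lies within the usual scatter, so nothing can be said about their order.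

Compound 3, `COc1cc2c(Oc3ccc(NC(=O)c4nn(-c5ccccc5C)cc(C)c4=O)cc3F)ccnc2cc1OCCCC(=O)NO`, has not yet been measured. Relative to compound 2 it carries one change, (methyl in place of fluoro on an aromatic carbon). The entering methyl is the same group that compound 1 carries at this place, and compound 1 gives 640 nM in this assay.

For the measured compounds named here, no step between two measured compounds is available to calibrate this exchange. Given that compound 1 and compound 2 sit within scatter of each other, the step from compound 2 to compound 3 is expected to be small, most likely no larger than the scatter, with no clear direction: a 1.4-fold lower number from compound 2 to compound 3 (0.15 log units; within the scatter). Compound 3 is therefore estimated at 800 nM in this assay, with a range from 350 nM to 1800 nM.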

Compound 3, half-maximal inhibitory concentration: 2040 nM
For compound 3 the middle estimate is 2.6-fold (0.41 log units) below the measured one; measured number outside the range, above it.
By their numbers in this assay, from the lowest: compounds 1, 2 and 3 (each within the scatter of the next, the first and the last beyond it).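

In this assay, the exchange of 2-fluorophenyl for 2-methylphenyl gives a 1.8-fold higher number from compound 2 to compound 3 (0.26 log units; within the scatter), so this first direct reading of methyl in place of fluoro, ortho to a large group, shows no effect that can be told apart from the scatter. For the compounds shown here, the larger step lies at another place in the molecule: with the 2-methylphenyl held constant, fluoro in place of hydrogen on an aromatic carbon gives a 3.2-fold higher number from compound 1 to compound 3 (0.50 log units; beyond the scatter), the only step so far that lies beyond the scatter, though a modest one. Nothing measured here accounts for either step.

The compounds shown leave open how a chlorine atom, a methoxy group or a plain hydrogen in the same place on that phenyl ring would read in this assay, as only fluoro and methyl have been compared there. On these data alone, each step also rests on a single pair of compounds, so it remains open whether fluoro in place of hydrogen would give a step of similar size with 2-fluorophenyl in place of 2-methylphenyl.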